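The source may report more compounds than this note shows. Statements on the series, on what has been measured and on what is new or still open speak of the compounds shown alone.

The measured compounds:

Compound 1, `CN(C)C(=O)[C@H]1CCC[C@@H](c2cccc(-n3ncc(C(=O)O)c3C3CC3)c2)C1`: 1.7
Compound 2, `CCCC1CCCCN1C(=O)c1cccc(-c2cccc(-n3ncc(C(=O)O)c3C3CC3c3cccnn3)c2)c1`: 2.9
Compound 3, `O=C(O)c1cnn(-c2cccc(-c3cccc(C(=O)N4CCCC5(CCCC5)C4)c3F)c2)c1C1CC1`: 3.7

In a physicochemical assay for lipophilicity, read by HPLC, at pH 2 (on this read-out higher numbers stand for higher lipophilicity and lower numbers for lower lipophilicity), these three compounds span a fair range. Compound 2, with 2.9, stands second highest of the three numbers. Its nearest neighbour is compound 3, whose 3.7 lies higher by an amount beyond the scatter; the furthest is compound 1, whose 1.7 lies lower, again beyond the scatter. Within the data shown here, no pair among the three differs in one place only, so no single structural step can be read from the measured set.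

Compound 4, `CCCC1CCCCN1C(=O)c1cccc(-c2cccc(-n3ncc(C(=O)O)c3C3CC3c3cccnc3)c2)c1`, has not yet been measured in this assay. It differs from compound 2 in one place:

pyridin-3-yl in place of pyridazin-3-yl on a saturated ring carbon

Among the measured compounds shown here, nothing among the measured compounds shows this exact change, so what follows is an expectation and not a reading. The account expects the step in this assay from compound 2 to compound 4 to be upward and beyond the scatter, moderate in size, a number 0.60 log units higher from compound 2 to compound 4 (beyond the scatter). Starting from compound 2 at 2.9, compound 4 is accordingly expected to give about 3.5, with the estimate ranging from 3 to 4.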

Compound 4, distribution coefficient: 3.9
Estimate against measurement, compound 4: 0.40 log units below, and the stated range covers the measured number.
By their numbers in this assay, from the lowest: compound 1; then compound 2; then compounds 3 and 4 (each within the scatter of the next).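

In this assay, among these compounds, the exchange of pyridazin-3-yl for pyridin-3-yl on a saturated ring carbon of the three-membered ring gives the first step in this set that can be read in one place, a number 1.00 log units higher from compound 2 to compound 4 (beyond the scatter), which the earlier compounds, none differing from another in one place only, could not show. It shows that the read-out responds at this position to a change within the aromatic ring alone: both groups have 6 heavy atoms and one six-membered aromatic ring, but 4 carbon and 2 nitrogen give way to 5 carbon and 1 nitrogen, with 1 hydrogen-bond acceptor in place of 2. No measurement at hand accounts for the size of this step.

The compounds shown leave open how pyridin-2-yl, pyridin-4-yl, a phenyl group or an amine would read on this same carbon. They also leave open whether the exchange would give a similar step with the remainder of the molecule changed, since the one step shown rests on a single pair of compounds.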